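Amide nitrogen substituent: from compound 3 to compound 4

This account rests on a few compounds, and the source may have more. Where it says the series, first, only, none or still open, it means among the compounds named here.

Measured in a functional assay on HCT-116 cells (Homo sapiens) for cytotoxicity, read by MTT assay; a higher number here means a weaker inhibitor, a lower number a stronger inhibitor
- compound 1 `CCn1cc(-c2nc3ccc([N+](=O)[O-])cc3o2)c(=O)c2cc(F)c(N3CCNC(C)C3)c(F)c21` gives 1100 nM
- compound 2 `CCn1cc(C(=O)Nc2ccccc2N)c(=O)c2cc(F)c(N3CCNC(C)C3)c(F)c21` gives 2700 nM
- compound 3 `CCn1cc(C(=O)Nc2ccc(C)c([N+](=O)[O-])c2)c(=O)c2cc(F)c(N3CCNC(C)C3)c(F)c21` gives 11800 nM

Compound 3 carries the highest number of the three. Compound 4 `CCn1cc(C(=O)NCc2ccc(OC)cc2)c(=O)c2cc(F)c(N3CCNC(C)C3)c(F)c21` has 4-methoxybenzyl in place of 4-methyl-3-nitrophenyl on an amide-type nitrogen and is still unmeasured. Among the measured compounds shown here, one measured step bears on this position, the modest 4.4-fold higher number from compound 2 to compound 3 (0.64 log units; beyond the scatter), and no measured compound carries a benzyl group. On the strength of that step from compound 2, a modest move toward a lower number is expected in this assay, namely a 2.4-fold lower number from compound 3 to compound 4 (0.37 log units; beyond the scatter) as the estimated step. Compound 4 is estimated at 5000 nM, with an expected range from 1800 nM to 15000 nM in this series.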

Compound 4, half-maximal inhibitory concentration: 1400 nM
Compound 4: middle estimate off by 3.6-fold (0.55 log units), on the high side; measured number outside the range, below it.
By their numbers in this assay, from the lowest: compounds 1, 4 and 2 (each within the scatter of the next, the first and the last beyond it); then compound 3.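

In this assay, moving to 4-methoxybenzyl on the amide nitrogen gives an 8.4-fold lower number from compound 3 to compound 4 (0.93 log units; beyond the scatter) and shows that the high number of compound 3 does not hold for every aromatic amide substituent. Replacing 2-aminophenyl with the same group gives a 1.9-fold lower number from compound 2 to compound 4 (0.29 log units; within the scatter) so that pair cannot be separated here. No measured data explain these results.

The change to compound 4 alters both the linking carbon and the ring substituents, so their separate contributions remain unresolved. Plain benzyl or phenethyl on this nitrogen would help separate them.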